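From Hydroxy to Methoxy on Compound 1

A few compounds are considered here, and "the series" means these few. Any claim that something is new, unique, unknown or untested is made for them only; others in the source may bear on it.

Within the data shown here, in an ADME assay on THP-1 cells (Homo sapiens) for cytotoxicity, read by flow cytometry and propidium iodide staining, with a stated time of 72 h (a higher number here means a weaker inhibitor, a lower number a stronger inhibitor), compound 1 `COc1cccc(-c2oc3ccc(NC(C)=O)cc3c(=O)c2O)c1` gives 50000 nM, the higher of the two numbers measured so far, while compound 2 `COc1ccc(-c2oc3ccc(NC(C)=O)cc3c(=O)c2O)cc1` gives 9000 nM. Compound 3 `COc1cccc(-c2oc3ccc(NC(C)=O)cc3c(=O)c2OC)c1` keeps the core of compound 1 and differs from it in one place: methyl in place of hydrogen on an oxygen on an aromatic ring. In words, this is methyl in place of hydrogen on an oxygen on an aromatic ring, which turns a hydroxy group into a methoxy group.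

Among the measured compounds shown here, only one measured step is available, a 5.6-fold lower number from compound 1 to compound 2 (0.74 log units; beyond the scatter). That step is modest but beyond the scatter, and it swaps 3-methoxyphenyl for 4-methoxyphenyl, so it does not test the hydroxy group at all. It serves only as a rough guide to how far one small change can move this number. For the measured compounds named here, no measured pair shows the direction of a hydroxy-to-methoxy change. The expected change is a 1.7-fold lower number from compound 1 to compound 3 (0.22 log units; within the scatter), leaning slightly lower, with little confidence in that direction. Compound 3 is therefore expected at 30000 nM, within an estimated range of 7000 nM to 100000 nM.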

Compound 3, half-maximal inhibitory concentration: 5000 nM
Beside the measured number, compound 3's estimate is 6.0-fold (0.78 log units) above it; measured number below the stated range.
By their numbers in this assay, from the lowest: compounds 3 and 2 (each within the scatter of the next); then compound 1.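

In this assay, the oxygen on the aromatic ring proves to be a sensitive place: turning the hydroxy group of compound 1 into a methoxy group gives a 10-fold lower number from compound 1 to compound 3 (1.00 log units; beyond the scatter), towards a stronger inhibitor. Among these compounds, the earlier step only swapped 3-methoxyphenyl for 4-methoxyphenyl and left this hydroxy group untouched, so this is the first measured sign that the oxygen matters, and that a change of just one carbon there can move the number beyond the scatter. The data at hand offer no measurement that explains why this small change has such an effect.

Open, on these data alone, is whether the shift comes from losing the hydroxy hydrogen or from gaining the methyl, since this single step changes both at once. Also open, as far as these compounds go, are whether the same change would act alike with the 4-methoxyphenyl group of compound 2, and how a longer chain such as ethyl on this oxygen, or an amine in place of the hydroxy group, would read in this assay.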